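Ethylsulfanyl for Methoxy on a Shared Core

The source may hold more compounds than are shown below. What is called first, only, known or untested is meant among the compounds shown, and "the series" means these compounds.

Compound 1 `Oc1ccccc1CNc1ccc(-c2ccc(F)cc2)nc1`: 2590 nM
Compound 2 `Oc1ccccc1CNc1ccc(-c2ccc(Cl)cc2)nc1`: "not active" (no number reported) (reported without a number)
Compound 3 `COc1ccc(-c2ccc(NCc3ccccc3O)cn2)cc1`: 4760 nM

In a functional assay on Jurkat cells (Homo sapiens) for activation, with a stated time of 24 h (on this read-out lower numbers stand for an effect already at smaller amounts and higher numbers for an effect only at larger amounts of compound), compound 3 gives 4760 nM, the higher of the two numbers available. Compound 1 gives 2590 nM, and the step of a 1.8-fold higher number from compound 1 to compound 3 (0.26 log units; within the scatter) lies within the scatter. Compound 2 is reported in this assay as "not active" (no number reported), with no number given. Compound 4 `CCSc1ccc(-c2ccc(NCc3ccccc3O)cn2)cc1` differs from compound 3 by ethylsulfanyl in place of methoxy on an aromatic carbon. For the measured compounds named here, no measured step exchanges a methoxy for an ethylsulfanyl; the only measured step on that carbon, a 1.8-fold higher number from compound 1 to compound 3 (0.26 log units; within the scatter), stays within the scatter, while compound 2 carrying chloro gives no number at all. A step of no clear size beyond the scatter is therefore expected in this assay, a modest rise being somewhat more likely than a fall. Compound 4 is estimated at 6000 nM, ranging from 2000 nM to 20000 nM, which means a step of a 1.3-fold higher number from compound 3 to compound 4 (0.10 log units; within the scatter).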

Compound 4, half-maximal effective concentration: 1920 nM
Compound 4: middle estimate off by 3.1-fold (0.49 log units), on the high side; measured number outside the range, below it.
By their numbers in this assay, from the lowest: compounds 4, 1 and 3 (each within the scatter of the next, the first and the last beyond it).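

In this assay, for the compounds shown here, the exchange of methoxy for ethylsulfanyl gives a 2.5-fold lower number from compound 3 to compound 4 (0.39 log units; beyond the scatter) and so is the first step on this aromatic carbon that lies beyond the scatter. Set against fluoro, the same ethylsulfanyl gives only a 1.3-fold lower number from compound 1 to compound 4 (0.13 log units; within the scatter) and leaves the two groups indistinguishable here. The data offer no measurement that would explain the step. From the compounds shown here alone, whether a longer chain such as propylsulfanyl or an amine on this carbon would lower the number further stays open. Also open is why compound 2, with chloro, gives no number while its fluoro counterpart, compound 1, does.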